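The source may hold more compounds than are shown below. What is called first, only, known or untested is meant among the compounds shown, and "the series" means these compounds.

Among the compounds with values here, compound 2 `CC/C(=C(/c1ccc(/C=C/C(=O)O)cc1)c1cc2ccccc2[nH]1)c1ccc(C(F)(F)F)cc1Cl` gives the lowest of the two numbers so far in a functional assay on MCF7 cells (Homo sapiens) for inhibition (a lower number here means a stronger inhibitor, a higher number a weaker inhibitor), with 27 nM; compound 1 `CC/C(=C(/c1ccc(/C=C/C(=O)O)cc1)c1cc2ccccc2[nH]1)c1ccc(OC)cc1` gives 61 nM. Within the data shown here, the single measured step, a 2.3-fold lower number from compound 1 to compound 2 (0.35 log units; beyond the scatter), replaced one aryl group by another. Compound 3 `CC/C(=C(/c1ccc(/C=C/C(=O)O)cc1)c1cc2ccccc2[nH]1)c1ccc(Cl)c(C(F)(F)F)c1` keeps the same atoms but joins them differently: 4-chloro-3-(trifluoromethyl)phenyl in place of 2-chloro-4-(trifluoromethyl)phenyl on a double-bonded chain carbon bound to a double-bonded chain carbon and a saturated chain carbon. Among the measured compounds shown here, no measured step moves substituents around a ring this way, so the step from compound 1 to compound 2 offers only indirect guidance. The expected change, a 1.5-fold higher number from compound 2 to compound 3 (0.17 log units; within the scatter), is therefore small, and compound 3 is estimated at 40 nM, within 15 nM to 110 nM.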

Compound 3, half-maximal inhibitory concentration: 2200 nM
For compound 3 the middle estimate is 55-fold (1.74 log units) below the measured one; the measured number lies above the stated range.
By their numbers in this assay, from the lowest: compound 2; then compound 1; then compound 3.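

In this assay, the aryl group on this double-bonded chain carbon proves far more sensitive than the first step suggested: rearranging the same atoms gives an 81-fold higher number from compound 2 to compound 3 (1.91 log units; beyond the scatter), a much larger change than any replacement seen before. Replacing 4-methoxyphenyl gives a 36-fold higher number from compound 1 to compound 3 (1.56 log units; beyond the scatter), so in these compounds the chlorine and trifluoromethyl do not on their own go with the lower number, and their arrangement counts. Nothing measured here bears on why the arrangement matters so much. The compounds shown leave open whether moving the chlorine or moving the trifluoromethyl accounts for the change. They also leave open how an amine or a nitrile on this ring would read.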